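A bromophenyl arm in place of the methoxyphenyl

The source may report more compounds than this note shows. Statements on the series, on what has been measured and on what is new or still open speak of the compounds shown alone.

Compound 1 `COc1cccc(-c2nc3cccc(-c4cc(OC)c(OC)c(OC)c4)c3o2)c1` stands at the edge of what a functional assay on U-251 cells (Homo sapiens) for antiproliferative activity, read by MTT assay, with a stated time of 48 h (on this read-out higher numbers stand for weaker inhibition and lower numbers for stronger inhibition), can report. In this assay compound 1 gives > 25000 nM, which is a limit of the assay rather than a number. Its two neighbours give numbers: compound 2 `COc1ccc(-c2nc3cccc(-c4cc(OC)c(OC)c(OC)c4)c3o2)cc1OC` gives 1300 nM, and compound 3 `COc1cc(-c2cccc3nc(-c4cccc(F)c4)oc23)cc(OC)c1OC` gives 2900 nM. Both an at least 19-fold lower number from compound 1 to compound 2 (1.28 log units; beyond the scatter) and an at least 8.6-fold lower number from compound 1 to compound 3 (0.93 log units; beyond the scatter) lead away from the limit, while a 2.2-fold higher number from compound 2 to compound 3 (0.35 log units; beyond the scatter) separates the two. Compound 4 `COc1cc(-c2cccc3nc(-c4ccc(Br)cc4)oc23)cc(OC)c1OC` differs from compound 1 by 4-bromophenyl in place of 3-methoxyphenyl on an aromatic carbon. The step from compound 1 to compound 3 is the closer precedent, as it too puts a halogen-bearing phenyl in place of the 3-methoxyphenyl, so a step of similar size in the same direction is expected. Compound 4 is estimated at 3000 nM, with a range from 800 nM to 12000 nM. That estimate means an expected step of an at least 8.3-fold lower number from compound 1 to compound 4 (0.92 log units; beyond the scatter).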

Compound 4, half-maximal inhibitory concentration: > 25000 nM
Compound 4: no number, only a limit; the forecaster's own chance of this, stated with the estimate: 15%; at least 8.3-fold (0.92 log units) between middle value and limit.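

In this assay, compound 4 gives only a limit and not a number, as compound 1 does: the limit of > 25000 nM in this assay, at which 2 of the 4 values shown sit.

The step between those two compounds cannot be read. Still, a halogen-bearing phenyl at this position does not guarantee a measurable value, as the result shows an at least 8.6-fold higher number from compound 3 to compound 4 (0.93 log units; beyond the scatter) and an at least 19-fold higher number from compound 2 to compound 4 (1.28 log units; beyond the scatter).

The 3-fluorophenyl and 4-bromophenyl arms differ both in the halogen and in where it sits, and these compounds do not separate the two. From the compounds shown here alone, it also remains open how a 3-bromophenyl or a 4-aminophenyl arm would behave here.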